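Hydrazones in the series: from compound 1 to compound 4

The compounds below may be only part of what the source reports. "The series", "measured", "known", "first", "only" and "open" are said of these compounds alone.

Measured in a physicochemical assay, read by spectrophotometry, with a stated time of 6 min; on this read-out lower numbers stand for stronger inhibition and higher numbers for weaker inhibition:
- compound 1 `O=C(CCc1nc2ccccc2c(=O)[nH]1)N/N=C/c1ccc([N+](=O)[O-])cc1`: 220000000 nM
- compound 2 `COc1cc(/C=N/NC(=O)CCCc2nc3ccccc3c(=O)[nH]2)cc(OC)c1O`: 135000000 nM
- compound 3 `O=C(CCCc1nc2ccccc2c(=O)[nH]1)N/N=C/c1ccc([N+](=O)[O-])cc1`: 270000000 nM

In this assay, compound 1 at 220000000 nM stands within the scatter of both other measured compounds, so the three numbers give no firm ranking around it. For the measured compounds named here, no step between measured compounds that differ in one place is available, so the set offers no direct guide to the effect of any single change.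

The next entry is compound 4 `COc1cc(/C=N/NC(=O)CCc2nc3ccccc3c(=O)[nH]2)ccc1O`. Its difference from compound 1 is 4-hydroxy-3-methoxyphenyl in place of 4-nitrophenyl on a carbon with a double bond to nitrogen. In words, this is 4-hydroxy-3-methoxyphenyl in place of 4-nitrophenyl on a carbon with a double bond to nitrogen.

Going by the values given here, compound 2, the one measured compound that also bears hydroxy and methoxy groups, reads 135000000 nM, which is within the scatter of compound 1. No step beyond the scatter is therefore expected in this assay, with at most a slight drift toward lower numbers. The expected change is a 1.4-fold lower number from compound 1 to compound 4 (0.14 log units; within the scatter), which would stay within the scatter. For compound 4 the estimated value is 160000000 nM, with an expected range of 75000000 nM to 320000000 nM.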

Compound 4, half-maximal inhibitory concentration: 95000000 nM
For compound 4 the middle estimate is 1.7-fold (0.23 log units) above the measured one; measured number inside the range.
By their numbers in this assay, from the lowest: compounds 4, 2, 1 and 3 (each within the scatter of the next, the first and the last beyond it).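

For the compounds shown here, compound 4 supplies the first step between two compounds that differ in one place: in this assay, 4-hydroxy-3-methoxyphenyl in place of 4-nitrophenyl on a carbon with a double bond to nitrogen gives a 2.3-fold lower number from compound 1 to compound 4 (0.36 log units; beyond the scatter) and so moves the read-out beyond the scatter. The earlier compounds shown here could not show this, as their numbers offered no single change to read; this position now counts as one where a change of group shifts the result toward stronger inhibition, though only modestly and with the rest of compound 1 kept as it is. No measurement at hand bears on what lies behind this step.

As far as these compounds go, it remains open whether the hydroxy group or the methoxy group alone would carry the step, and how a 4-aminophenyl or 4-carboxyphenyl group would read on the same carbon. From the compounds shown here alone, whether the same change gives a step of this size on the chain of compound 3 is also open, since compound 2 and compound 3 differ in more than one place.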